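The source may hold more compounds than are shown below. What is called first, only, known or untested is meant among the compounds shown, and "the series" means these compounds.

Measured compounds:
- compound 1, `COc1ccc(C(=O)c2cc(OC)c(OC)c(OC)c2)cc1N`, a functional assay on HeLa cells (Homo sapiens) for cytotoxicity, read by MTT assay, with a stated time of 72 h; a lower number here means a stronger inhibitor, a higher number a weaker inhibitor: 60 nM
- compound 2, `COc1cccc(/C=C/C(=O)Nc2cc(OC)c(OC)c(OC)c2)c1`, this assay: 12300 nM
- compound 3, `COc1ccc(C(=O)c2cc(OC)c(OC)c(OC)c2)cc1NC(=O)/C=C/c1cc(OC)c(OC)c(OC)c1`, this assay: 1500 nM

Of the three values, compound 3 holds the second highest. Its nearest neighbour is compound 2, whose value lies above it by a gap that is beyond the usual scatter; compound 1 is furthest from it, with a value well below that of compound 3, again beyond the scatter. Compound 3 is thus the middle member of this set, and the amine compound 1 is the only one of the three with a low number.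

Compound 4, `COc1ccc(/C=C/C(=O)Nc2cc(C(=O)c3cc(OC)c(OC)c(OC)c3)ccc2OC)cc1`, has not yet been measured. It differs from compound 3 in one place: 4-methoxyphenyl in place of 3,4,5-trimethoxyphenyl on a double-bonded chain carbon bound to a double-bonded chain carbon. Going by the values given here, no step between measured compounds follows this exact change, so the size of the expected step rests on the structural change alone. One of the two trimethoxyphenyl groups of compound 3 is reduced to a single methoxy substituent; a modest rise in this assay, perhaps within or just beyond the scatter, is the expectation, so the estimated step is a 1.7-fold higher number from compound 3 to compound 4 (0.22 log units; within the scatter). Compound 4 is accordingly expected to give about 2500 nM, within a range from 600 nM to 10000 nM.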

Compound 4, half-maximal inhibitory concentration: 10700 nM
Estimate against measurement, compound 4: 4.3-fold (0.63 log units) below, and the stated range ends below it.
By their numbers in this assay, from the lowest: compound 1; then compound 3; then compounds 4 and 2 (each within the scatter of the next).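

In this assay, putting 4-methoxyphenyl in place of 3,4,5-trimethoxyphenyl on a double-bonded chain carbon bound to a double-bonded chain carbon gives a 7.1-fold higher number from compound 3 to compound 4 (0.85 log units; beyond the scatter), a step beyond the usual scatter. Going by these compounds alone, the earlier compounds included no pair differing in one place, so this is the first direct reading of this position, and it shows that the number in this assay responds to the substitution of this phenyl group even though the rest of the molecule stays the same. Nothing available here accounts for the size of this step.

The compounds shown leave open whether a 3,4-dimethoxyphenyl, a 4-hydroxyphenyl or an unsubstituted phenyl group at this place would give a number closer to that of compound 3 or to that of compound 4, and so how the step is shared among the methoxy groups that leave. Also open, going by these compounds, is how a small acetyl group on the amine of compound 1, which itself gives 60 nM, would read in this assay.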